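Side-chain stereocentre inversion in the amino acid quinone series

The source may hold more compounds than are shown below. What is called first, only, known or untested is meant among the compounds shown, and "the series" means these compounds.

Measured in an ADME assay on KB cells (Homo sapiens) for cytotoxicity, with a stated time of 48 h; a lower number here means a stronger inhibitor, a higher number a weaker inhibitor:
- compound 1 `C=C1[C@H](C)CCC[C@]1(C)CC/C(C)=C/CC1=C(O)C(=O)C=C(N[C@@H](C(=O)O)[C@H](C)O)C1=O`: > 10 ug/mL (a limit)
- compound 2 `CC1=CCC[C@](C)(CC/C(C)=C/CC2=C(O)C(=O)C=C(N[C@@H](CO)C(=O)O)C2=O)[C@@H]1C`: > 10 ug/mL (a limit)

Compound 1 stands only at a limit in this assay, with no number behind it, at > 10 ug/mL. Compound 2 is also reported only as a limit. Together they give (the limit of > 10 ug/mL in this assay, at which 2 of the 2 values shown sit).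

The next compound to be read is compound 3 `C=C1[C@H](C)CCC[C@]1(C)CC/C(C)=C/CC1=C(O)C(=O)C=C(N[C@H](C(=O)O)[C@H](C)O)C1=O`. Its change from compound 1 is purely one of configuration: the two compounds have the same atoms and bonds and differ only in configuration as drawn: 1 of 5 stereo elements differ; a stereocentre at a saturated chain carbon is drawn R in compound 1 and S in compound 3. Among the measured compounds shown here, no measured pair shows what such an inversion does. No step beyond the scatter is therefore expected in this assay, in either direction, and another limit is the likeliest report. This expectation rests on (the limit of > 10 ug/mL in this assay, at which 2 of the 2 values shown sit), which covers compound 1 and compound 2. The expected change is a step that the limit leaves unreadable from compound 1 to compound 3. For compound 3 the estimated value is 15 ug/mL, with an expected range of 10 ug/mL to 40 ug/mL.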

Compound 3, half-maximal inhibitory concentration: > 10 ug/mL
Compound 3 gave a limit, no number; the forecaster's own chance of this, stated with the estimate: 85%; the middle value is on the limit's open side.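

In this assay compound 3 gives > 10 ug/mL, a limit, and compound 1 is also reported only as a limit, so no step can be read between compound 1 and compound 3. The compounds shown leave open what inverting the stereocentre at the saturated chain carbon does in this assay.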